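The source may report more compounds than this note shows. Statements on the series, on what has been measured and on what is new or still open speak of the compounds shown alone.

Measured so far in a functional assay on Daoy cells (Homo sapiens) for antiproliferative activity, read by trypan blue exclusion and crystal violet staining, with a stated time of 72 h (on this read-out higher numbers stand for weaker inhibition and lower numbers for stronger inhibition), for this series:
- compound 1 `CCCCC(=O)NCc1ccc2cccnc2c1O` gives "nd" (no result reported) with no number to compare
- compound 2 `CCCCC(=O)NC(c1cc(Cl)cc(Cl)c1)c1ccc2cccnc2c1O` gives 140 nM as the sole figure

Compound 2 therefore stands alone on the numbers, with nothing to rank it against. Compound 3 `CCCCC(=O)NC(c1ccc(Cl)c(Cl)c1)c1ccc2cccnc2c1O` has the same atoms as compound 2, joined differently. The change 3,4-dichlorophenyl in place of 3,5-dichlorophenyl on a saturated chain carbon bound to an amide-type nitrogen and an aromatic carbon puts 3,4-dichlorophenyl in place of 3,5-dichlorophenyl on a saturated chain carbon bound to an amide-type nitrogen and an aromatic carbon. For the measured compounds named here, no measured step shows what such a move does, so no direction can be argued and no shift beyond the scatter is expected in this assay here. The expectation rests on compound 2 at 140 nM alone. The estimated 1.1-fold higher number from compound 2 to compound 3 (0.03 log units; within the scatter) is expected to stay within the usual scatter. Compound 3 is expected at 150 nM within an estimated range of 60 nM to 380 nM for now.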

Compound 3, half-maximal inhibitory concentration: 100 nM
Estimate against measurement, compound 3: 1.5-fold (0.18 log units) above, and the stated range covers the measured number.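

In this assay, the step at this position, on a saturated chain carbon bound to an amide-type nitrogen and an aromatic carbon, is a 1.4-fold lower number from compound 2 to compound 3 (0.15 log units; within the scatter). This first readable step shows that 3,4-dichlorophenyl in place of 3,5-dichlorophenyl leaves the read-out within the scatter, so the two chlorine patterns cannot be told apart in this assay. Nothing available bears on the reason for this result.

As far as these compounds go, compound 1 gives "nd" (no result reported), so the step from it to compound 2 cannot be read, and what the dichlorophenyl group adds to the core of compound 1 stays unknown. Also open, from the compounds shown here alone, is what an unsubstituted phenyl, a methoxyphenyl or a pyridyl ring would do at this place, and what a longer chain on the amide carbonyl would do.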